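Ester chain length in a dihydropyridine imidazole series

The source may hold more compounds than are shown below. What is called first, only, known or untested is meant among the compounds shown, and "the series" means these compounds.

Measured compounds:
compound 1 `CCCOC(=O)C1=C(C)NC(C)=C(C(=O)OCCC)C1c1[nH]c(CC)nc1Cl` gives 0.13 nM
compound 2 `CCc1nc(Cl)c(C2C(C(=O)OC)=C(C)NC(C)=C2C(=O)OC(C)C)[nH]1` gives 0.488 nM
compound 3 `CCc1nc(Cl)c(C2C(C(=O)OC)=C(C)NC(C)=C2C(=O)OC(C)(C)C)[nH]1` gives 50.8 nM

All three were run in an assay on ileum for inhibition of Voltage-dependent L-type calcium channel subunit alpha-1C (Cavia porcellus); on this read-out higher numbers stand for weaker inhibition and lower numbers for stronger inhibition. The difference between the core of compound 1 and the core of compound 3 is not broken down here. One structural change, (hydrogen in place of methyl on a saturated chain carbon bound to an oxygen next to a carbonyl group and two saturated chain carbons), gave the step of a 100-fold lower number from compound 3 to compound 2 (2.02 log units; beyond the scatter). Compound 4 `CCCOC(=O)C1=C(C)NC(C)=C(C(=O)OCC)C1c1[nH]c(CC)nc1Cl` is not yet measured; it differs from compound 1 by hydrogen in place of methyl on a saturated chain carbon, two bonds along the chain from an oxygen next to a carbonyl group. Within the data shown here, this is the same kind of change as the one from compound 3 to compound 2, but not the same: there the place was a saturated chain carbon bound to an oxygen next to a carbonyl group and two saturated chain carbons, here a saturated chain carbon two bonds along the chain from such an oxygen. A smaller step is expected from compound 1 to compound 4, a 1.5-fold higher number from compound 1 to compound 4 (0.19 log units; within the scatter), because compound 1 at 0.13 nM and compound 2 at 0.488 nM differ little across several changes. Compound 4 is estimated at 0.2 nM (range 0.07 nM to 0.6 nM).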

Compound 4, half-maximal inhibitory concentration: 0.543 nM
Compound 4: middle estimate off by 2.7-fold (0.43 log units), on the low side, and the stated range covers the measured number.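

In this assay, propyl to ethyl on the core of compound 1 gave a 4.2-fold higher number from compound 1 to compound 4 (0.62 log units; beyond the scatter), so here the loss of the methyl weakens inhibition, whereas the same kind of change on the other core went the opposite way: the same change on two cores in this assay, a 100-fold lower number (2.02 log units; beyond the scatter) from compound 3 to compound 2 and a 4.2-fold higher number (0.62 log units; beyond the scatter) from compound 1 to compound 4, 430-fold (2.64 log units) apart, beyond the scatter of two such steps

The change therefore does not carry over in size or direction between these two steps. It does not show whether core or place accounts for the gap, since the steps differ in both: one lies on a saturated chain carbon bound to an oxygen next to a carbonyl group and two saturated chain carbons, the other two bonds along the chain from such an oxygen.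

Still open, on these data alone, is how a longer chain, such as a butyl ester, would read on the core of compound 1. The compounds shown also leave open whether a methyl ester in place of the ethyl ester of compound 4 would continue the same trend.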